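The source may hold more compounds than are shown below. What is called first, only, known or untested is meant among the compounds shown, and "the series" means these compounds.

Measured compounds in a functional assay on NCI-H1975 cells (Homo sapiens) for inhibition; on this read-out lower numbers stand for stronger inhibition of growth and higher numbers for weaker inhibition of growth:
compound 1, `O=C(/C=C/CN1CCCCC1)Nc1cc2c(Nc3ccc(F)c(Cl)c3)ncnc2cc1O[C@H]1CCOC1`, for which compound 1 gives 168 nM;
compound 2, `COc1cc2ncnc(Nc3ccc(F)c(Cl)c3)c2cc1NC(=O)/C=C/CN(C)C1CC1`, for which compound 2 gives 32.2 nM;
compound 3, `C#Cc1cccc(Nc2ncnc3cc(O[C@H]4CCOC4)c(NC(=O)/C=C/CN4CCCCC4)cc23)c1`, for which compound 3 gives 40.1 nM.

Compound 3 is made from compound 1 by 3-ethynylphenyl in place of 3-chloro-4-fluorophenyl on a nitrogen on an aromatic ring, and in this assay that change gave a 4.2-fold lower number from compound 1 to compound 3 (0.62 log units; beyond the scatter). Compound 2 and compound 1 carry different cores; the difference between the two cores is not broken down here. Compound 4, `C#Cc1cccc(Nc2ncnc3cc(OC)c(NC(=O)/C=C/CN(C)C4CC4)cc23)c1`, is not yet measured. For the measured compounds named here, it is made from compound 2 by 3-ethynylphenyl in place of 3-chloro-4-fluorophenyl on a nitrogen on an aromatic ring, the same change at the same place as the one seen from compound 1 to compound 3. Resting on a 4.2-fold lower number from compound 1 to compound 3 (0.62 log units; beyond the scatter), the step from compound 2 to compound 4 in this assay is expected to be a 2.7-fold lower number from compound 2 to compound 4 (0.43 log units; beyond the scatter), somewhat damped since compound 2 already gives 32.2 nM. For compound 4 in this assay the estimate is 12 nM, expected to fall between 5 nM and 30 nM.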

Compound 4, concentration for 50% growth inhibition: 70.5 nM
Estimate against measurement, compound 4: 5.9-fold (0.77 log units) below; the measured number lies above the stated range.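

In this assay, putting 3-ethynylphenyl in place of 3-chloro-4-fluorophenyl gave a 2.2-fold higher number from compound 2 to compound 4 (0.34 log units; beyond the scatter), so the change did not carry over from the earlier pair with its direction intact. Set side by side, the two steps differ: the same change on two cores in this assay, a 4.2-fold lower number (0.62 log units; beyond the scatter) from compound 1 to compound 3 and a 2.2-fold higher number (0.34 log units; beyond the scatter) from compound 2 to compound 4, 9.2-fold (0.96 log units) apart, beyond the scatter of two such steps. This shows that, across these two pairs, the result of the change depends on the core that carries it, but it does not show which part of the core is responsible, as the two cores differ in more than one place.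

The compounds shown leave open whether the alkoxy group on the ring or the amine at the end of the side chain governs the reversal. They also leave open which way the change would go on a core whose side chain ends in a morpholine.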